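The compounds below may be only part of what the source reports. "The series", "measured", "known", "first", "only" and "open" are said of these compounds alone.

Compound 1 `Fc1ccc(OC[C@@H]2CCN2)cn1`: 0.057 nM; compound 2 `N#Cc1ccc(OC[C@@H]2CCN2)cn1`: 1.9 nM; compound 3 `FC(F)(F)c1cncc(OC[C@@H]2CCN2)c1`: 0.49 nM, all in an assay on brain for binding affinity to Neuronal acetylcholine receptor; alpha4/beta2 (Rattus norvegicus), read by radioligand binding; on this read-out lower numbers stand for stronger inhibition and higher numbers for weaker inhibition.

Compound 3 stands second highest of the three numbers in this assay: compound 2 sits above it, compound 1 below it. Compound 4 `CCCc1cncc(OC[C@@H]2CCN2)c1` differs from compound 3 by propyl in place of trifluoromethyl on an aromatic carbon. Among the compounds with values here, the only measured step, a 33-fold higher number from compound 1 to compound 2 (1.52 log units; beyond the scatter), concerns a different group at a different place on the shared core, so no measured step bears directly on this change. The expectation therefore rests on the spread of the three numbers alone, and a moderate weakening is estimated, a 4.1-fold higher number from compound 3 to compound 4 (0.61 log units; beyond the scatter). Compound 4 is expected to give about 2 nM in this assay, within a range from 0.3 nM to 15 nM.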

Compound 4, inhibition constant: 0.039 nM
The estimate for compound 4 lay 51-fold (1.71 log units) above the measured number; the whole stated range lies above it.
By their numbers in this assay, from the lowest: compounds 4 and 1 (each within the scatter of the next); then compound 3; then compound 2.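

At this aromatic carbon, two atoms from the ring nitrogen, propyl in place of trifluoromethyl gives much stronger binding in this assay, with a 13-fold lower number from compound 3 to compound 4 (1.10 log units; beyond the scatter). Within the data shown here, the earlier compounds held no change at this position, so this is the first sign that the position accepts a plain carbon chain and that fluorine is not needed there for strong binding.

On these data alone, whether a longer chain such as butyl, or an amine, would keep the number this low remains open. Nothing measured here explains the size of this step.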